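Acylsulfonamide replacement at the amide nitrogen of compound 3

The source may report more compounds than this note shows. Statements on the series, on what has been measured and on what is new or still open speak of the compounds shown alone.

The series shares one core. Compound 1 `Cc1cc(C)cc(S(=O)(=O)c2c(C(=O)N[C@H]3CCN(Cc4cccnc4)C3)[nH]c3ccc(Cl)cc23)c1` gives 22800 nM in an ADME assay on MT4 cells (Homo sapiens) for cytotoxicity, read by MTT assay, with a stated time of 5 days; a higher number here means that more compound is tolerated, a lower number that less compound is tolerated. Compound 2 `Cc1cc(C)cc(S(=O)(=O)c2c(C(=O)NC3CN(Cc4ccccc4C#N)C3)[nH]c3ccc(Cl)cc23)c1` gives only a limit in this assay, > 234000 nM, and sits at the limit of > 234000 nM in this assay, at which 1 of the 3 values shown sits. Compound 3 `Cc1cc(C)cc(S(=O)(=O)c2c(C(=O)NC3CN(CC(N)=O)C3)[nH]c3ccc(Cl)cc23)c1` gives 25500 nM in this assay, the higher of the two numbers, though its nearest neighbour compound 1 lies within the scatter: a 1.1-fold higher number from compound 1 to compound 3 (0.05 log units; within the scatter). The other step, an at least 9.1-fold lower number from compound 2 to compound 3 (0.96 log units; beyond the scatter), is at least modest.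

Compound 4 `Cc1cc(C)cc(S(=O)(=O)c2c(C(=O)NS(=O)(=O)c3ccccc3)[nH]c3ccc(Cl)cc23)c1` differs from compound 3 in one place: phenylsulfonyl in place of 1-(carbamoylmethyl)azetidin-3-yl on an amide-type nitrogen. For the measured compounds named here, neither measured step replaces the whole amine-bearing ring with an aryl sulfonyl group, so no measured step bears directly on this change. The two steps only show that exchanges at this side of the core move this assay by little or by a modest amount. The expected step is therefore a 1.2-fold higher number from compound 3 to compound 4 (0.07 log units; within the scatter), with a wide range. Compound 4 is estimated at 30000 nM, between 8000 nM and 150000 nM.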

Compound 4, half-maximal cytotoxic concentration: 167000 nM
Compound 4: the middle estimate sits 5.6-fold (0.75 log units) below what was measured, and the stated range ends below it.
By their numbers in this assay, from the lowest: compounds 1 and 3 (each within the scatter of the next); then compound 4. At a limit, above all of these: compound 2.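

In this assay, phenylsulfonyl on the amide-type nitrogen gives a 6.5-fold higher number from compound 3 to compound 4 (0.82 log units; beyond the scatter), and in place of 1-((pyridin-3-yl)methyl)pyrrolidin-3-yl it gives a 7.3-fold higher number from compound 1 to compound 4 (0.86 log units; beyond the scatter). The earlier exchange between these two amine-bearing groups stayed within the scatter, whereas these two steps show that this position can move the number beyond the scatter when the amine-bearing ring gives way to an aryl sulfonyl group. Compound 2 still gives only a limit, so it cannot be ranked against compound 4: the limit of > 234000 nM in this assay, at which 1 of the 4 values shown sits.

The compounds shown do not separate the sulfonyl link from the phenyl ring, which a methylsulfonyl or a benzoyl group on this nitrogen would do. They also leave open whether the higher number survives a carboxylic acid or an amine on the phenyl ring.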